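This account rests on a few compounds, and the source may have more. Where it says the series, first, only, none or still open, it means among the compounds named here.

Measured so far in a functional assay on HL-60 cells (Homo sapiens) for antiproliferative activity, read by MTT assay, with a stated time of 48 h; a lower number here means a stronger inhibitor, a higher number a weaker inhibitor:

Compound 1 `CN(C)CCCn1c(N)c(-c2nc3ccccc3s2)c2nc(C#N)c(C#N)nc21`: 510 nM
Compound 2 `CCN(CC)CCn1c(N)c(-c2nc3cc(Cl)ccc3[nH]2)c2nc(C#N)c(C#N)nc21`: > 50000 nM

Compound 2 has no exact number in this assay, and its result of > 50000 nM is only a limit. That limit is the ceiling of the data so far: the limit of > 50000 nM in this assay, at which 1 of the 2 values shown sits.

Compound 3 `CN(C)CCCn1c(N)c(-c2nc3cc(Cl)ccc3[nH]2)c2nc(C#N)c(C#N)nc21` has not yet been measured. It departs from compound 2 in one place: (dimethylamino)methyl in place of diethylamino on a saturated chain carbon, two bonds along the chain from an aromatic nitrogen. A (dimethylamino)methyl stands in place of diethylamino on a saturated chain carbon, two bonds along the chain from an aromatic nitrogen. Cut one bond further out, 2-(diethylamino)ethyl becomes 3-(dimethylamino)propyl.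

Among the measured compounds shown here, no measured pair shows this change on its own, so any forecast rests on thin ground. The 3-(dimethylamino)propyl chain also occurs in compound 1, which gives 510 nM, and this points to some gain in this assay. The expected change is towards stronger inhibition, an estimated at least 8.3-fold lower number from compound 2 to compound 3 (0.92 log units; beyond the scatter), though it may well be modest. For compound 3 the estimate is 6000 nM, with an expected range from 800 nM to 40000 nM.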

Compound 3, half-maximal inhibitory concentration: 2930 nM
Beside the measured number, compound 3's estimate is 2.0-fold (0.31 log units) above it; the measured number falls inside the stated range.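

In this assay, placing (dimethylamino)methyl in place of diethylamino on a saturated chain carbon, two bonds along the chain from an aromatic nitrogen, gives an at least 17-fold lower number from compound 2 to compound 3 (1.23 log units; beyond the scatter), so this change alone brings the series from no exact reading to a measurable value. Compound 2 gives only a limit, so the full size of this step stays unknown: the limit of > 50000 nM in this assay, at which 1 of the 3 values shown sits.

With the 3-(dimethylamino)propyl chain held fixed, 5-chloro-1H-benzimidazol-2-yl in place of 1,3-benzothiazol-2-yl on an aromatic carbon gives a 5.7-fold higher number from compound 1 to compound 3 (0.76 log units; beyond the scatter), which shows that in this assay the chain alone does not set the value and that the aromatic group also counts.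

The step from compound 2 changes the chain length and the groups on the amine together, and the compounds shown do not separate the two; a 2-(dimethylamino)ethyl or a 3-(diethylamino)propyl chain on the same core would do so. Also open, going by these compounds, is whether a cyclic amine such as morpholine at the chain end, or the 5-chloro-1H-benzimidazol-2-yl group without its chlorine, would hold or shift the value.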